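This account rests on a few compounds, and the source may have more. Where it says the series, first, only, none or still open, it means among the compounds named here.

Compound 1 (`OC[C@H]1O[C@@H](n2cnc3c(NCc4ccccc4Cl)ncnc32)[C@H](O)[C@@H]1O`) has no number in a functional assay on G-361 cells (Homo sapiens) for antiproliferative activity, with a stated time of 72 h; a lower number here means a stronger inhibitor, a higher number a weaker inhibitor: its entry reads "not determined" (no result reported). The only reference on this scale comes from compound 2 (`OC[C@H]1O[C@@H](n2cnc3c(NCc4ccc(F)cc4F)ncnc32)[C@H](O)[C@@H]1O`), which carries a second substituent pattern on the same shared core. Compound 2 gives no exact figure, only a limit of > 166000 nM.

The next compound is compound 3 (`OC[C@H]1O[C@@H](n2cnc3c(NCc4ccccc4OC(F)(F)F)ncnc32)[C@H](O)[C@@H]1O`). The structural change is trifluoromethoxy in place of chloro on an aromatic carbon, with trifluoromethoxy in place of chloro on an aromatic carbon, ortho to a large group. Among the compounds with values here, no measured step exists to size this change. Resting on compound 2 and its limit of > 166000 nM, the expectation in this assay is weak inhibition, with only a modest step, if any, toward the stronger side of that limit. For compound 3 the estimated value is 60000 nM, with an expected range from 8000 nM to 166000 nM.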

Compound 3, half-maximal inhibitory concentration: > 166000 nM
Compound 3: no number, only a limit; the forecaster's own chance of this, stated with the estimate: 60%; middle value at least 2.7-fold (0.44 log units) from the limit.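

In this assay compound 3 gives only a limit, > 166000 nM. No step can be read between compound 1, which has no number, and compound 3. Whether changing the substituent on the aromatic ring alters the activity stays open, as the values shown stop at one limit: the limit of > 166000 nM in this assay, at which 2 of the 3 values shown sit.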